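The compounds below may be only part of what the source reports. "The series", "measured", "known", "first", "only" and "open" are said of these compounds alone.

Working notes on the series. Three members are measured. Compound 1 `COc1ccc(C2=NC(=O)/C(=C/c3cc4ccccc4[nH]3)S2)cc1` gives in an assay on cells for inhibition of Polyunsaturated fatty acid 5-lipoxygenase (Homo sapiens), read by HPLC, with stated times of 15 min and 10 min (on this read-out lower numbers stand for stronger inhibition and higher numbers for weaker inhibition), a value of 670 nM. Compound 2 `COc1ccc(/C=C2\SC(c3ccc(C(=O)c4ccccc4)cc3)=NC2=O)cc1` gives in this assay a value of 440 nM, the lowest number among the three; its gap to compound 1 lies within the scatter, so the two cannot be ordered, whereas its gap to compound 3 lies beyond the scatter. Compound 3 `COc1ccc(/C=C2\SC(c3ccc(Oc4ccccc4)cc3)=NC2=O)c2ccccc12` gives in this assay a value of 2150 nM. For the measured compounds named here, no pair of measured compounds differs in a single place, so no measured step is available to read the next change from.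

The unmeasured compound 4 `COc1ccc(/C=C2\SC(c3ccc(F)cc3)=NC2=O)cc1` differs from compound 2 in one place: fluoro in place of benzoyl on an aromatic carbon. Going by the values given here, the data hold no step that shows what the loss of a group of this size does on this core. The step from compound 2 to compound 4 in this assay is expected to be a 2.3-fold higher number from compound 2 to compound 4 (0.36 log units; beyond the scatter), a moderate rise in the number, with wide uncertainty. Compound 4 is estimated at 1000 nM, with a range from 400 nM to 3000 nM.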

Compound 4, half-maximal inhibitory concentration: 200 nM
Compound 4: middle estimate off by 5.0-fold (0.70 log units), on the high side, and the stated range ends above it.
By their numbers in this assay, from the lowest: compound 4; then compounds 2 and 1 (each within the scatter of the next); then compound 3.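

Fluoro in place of benzoyl on this aromatic carbon gives a 2.2-fold lower number from compound 2 to compound 4 (0.34 log units; beyond the scatter) in this assay, so the benzoyl group, with its six-membered aromatic ring of carbon only, is not required at this place for inhibition on the shared core. On this one pair, the much smaller substituent gives the lower number, and no wider trend can be drawn from a single step. The data shown offer no measurement that would explain this step.

As far as these compounds go, whether the lower number comes with fluoro itself or simply with the removal of benzoyl stays open, and a plain hydrogen or a chloro on this carbon would separate the two. From the compounds shown here alone, it also remains open how an amine or a carboxylic acid at this place would read.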